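The compounds below may be only part of what the source reports. "The series", "measured", "known", "first", "only" and "open" are said of these compounds alone.

Working notes on the series.

Compound 2 `COc1nc2ccc(Br)cc2cc1C(c1ccccc1)n1cc(CCO)nn1` is the lower of the two measured compounds in an ADME assay on HEK293 cells (Homo sapiens) for cytotoxicity, read by sulforhodamine B assay, with a stated time of 48 h, tested at 10 uM (a higher number here means more inhibition at the concentration tested (going by the name of the read-out), a lower number less inhibition), giving 4.54%. For the measured compounds named here, its nearest neighbour is compound 1 `CCCCCCCCc1cn(C(c2ccccc2)c2cc3cc(Br)ccc3nc2OC)nn1`, which in this assay gives 14.6%; the only measured step, a number 10.1 percentage points lower from compound 1 to compound 2 (beyond the scatter), runs between these two and exchanges a hexyl for a hydroxy two bonds along the chain from an aromatic carbon.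

The next compound, compound 3 `COc1nc2ccc(Br)cc2cc1C(c1ccccc1)n1cc(CO)nn1`, takes the step from compound 2 by hydroxy in place of hydroxymethyl on a saturated chain carbon bound to an aromatic carbon. The same difference, cut one bond further out, reads 2-hydroxyethyl to hydroxymethyl on the triazolyl. Going by the values given here, no measured step of this kind exists: the one step known, a number 10.1 percentage points lower from compound 1 to compound 2 (beyond the scatter), concerns the hexyl-to-hydroxy exchange, and it says nothing direct about shortening a hydroxyalkyl chain by one carbon. Both compound 2 and compound 3 carry a hydroxy-bearing chain, so no step beyond the scatter is expected in this assay for compound 3. The estimate for compound 3 is 6%, with a range of -6% to 18%, which means an expected step of a number 1.5 percentage points higher from compound 2 to compound 3 (within the scatter).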

Compound 3, a percentage reported as inhibition, at one concentration (the size of the read-out at that concentration, not a potency): 11.5%
Compound 3: the middle estimate sits 5.5 percentage points below what was measured; measured number inside the range.
By their numbers in this assay, from the lowest: compounds 2, 3 and 1 (each within the scatter of the next, the first and the last beyond it).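

In this assay, for the compounds shown here, the change from 2-hydroxyethyl to hydroxymethyl on the triazolyl gives a number 7 percentage points higher from compound 2 to compound 3 (within the scatter), so this first comparison of hydroxy-bearing chains at this position shows no step that stands clear of the scatter. The exchange of heptyl for hydroxy on a saturated chain carbon bound to an aromatic carbon gives a number 3.1 percentage points lower from compound 1 to compound 3 (within the scatter), also within the scatter, while a number 10.1 percentage points lower from compound 1 to compound 2 (beyond the scatter) remains beyond it; the separation seen with the 2-hydroxyethyl chain therefore does not extend to compound 3, which goes against any reading that a hydroxy-bearing chain in place of the long alkyl chain sets the number apart. No supporting data bear on why these steps differ.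

With the shared core held fixed, the compounds shown leave open whether a longer hydroxyalkyl chain, such as 3-hydroxypropyl, would continue to fall within the scatter of compound 2 and compound 3. They also leave open whether replacing the hydroxy with an amine or a carboxylic acid at this position would give a step beyond the scatter in this assay.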